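A smaller aromatic ring in place of 4-phenylphenyl

A few compounds are considered here, and "the series" means these few. Any claim that something is new, unique, unknown or untested is made for them only; others in the source may bear on it.

Compound 1 `Cc1cc(C#N)cc(C)c1Oc1nc(Nc2ccc(C#N)cc2)ncc1-c1ccc(Cl)cc1`: 72600 nM
Compound 2 `Cc1cc(C#N)cc(C)c1Oc1nc(Nc2ccc(C#N)cc2)ncc1-c1ccc(-c2ccccc2)cc1`: > 253000 nM

Both compounds were tested in an ADME assay on MT4 cells (Homo sapiens) for cytotoxicity, read by MTT assay, with a stated time of 5 days; a lower number here means that less compound is tolerated, a higher number that more compound is tolerated. Compound 1 gives 72600 nM. For compound 2 the assay reports no number but only a limit, > 253000 nM. Among the compounds with values here, the single measured step, an at least 3.4-fold higher number from compound 1 to compound 2 (0.54 log units; beyond the scatter), is therefore itself only a lower bound on the change, because compound 2 sits at the limit of > 253000 nM in this assay, at which 1 of the 2 values shown sits.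

Compound 3 `Cc1cc(C#N)cc(C)c1Oc1nc(Nc2ccc(C#N)cc2)ncc1-c1cncnc1` has not yet been measured. The change from compound 2 is pyrimidin-5-yl in place of 4-phenylphenyl on an aromatic carbon. Within the data shown here, only the step from compound 1 to compound 2 bears on this: there, replacing chloro with phenyl on the same ring raised the tolerated amount by at least a modest margin. Compound 3 takes away that phenyl and the ring it sat on, replacing both with a single ring carrying two nitrogen atoms. The expectation is that the tolerated amount falls back part of the way toward compound 1, an estimated at least 2.1-fold lower number from compound 2 to compound 3 (0.32 log units; beyond the scatter), with a fair chance that the assay again reports only a limit. Compound 3 is thus estimated at 120000 nM, between 40000 nM and 300000 nM.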

Compound 3, half-maximal cytotoxic concentration: > 298000 nM
Compound 3 was reported as a limit (the forecaster's own chance of this, stated with the estimate: 35%); at least 2.4-fold (0.39 log units) between middle value and limit.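

In this assay, compound 3 gives > 298000 nM, and this value is a limit, not a number. Even so, the comparison with the chloro compound can be read: pyrimidin-5-yl in place of 4-chlorophenyl gives an at least 4.1-fold higher number from compound 1 to compound 3 (0.61 log units; beyond the scatter), beyond the usual scatter. Compound 2 had left open whether the higher number needed the extra carbon ring of 4-phenylphenyl, but compound 3 shows that a single six-membered ring with two nitrogen atoms, carrying no second ring, also stands clear of compound 1. The step between compound 2 and compound 3 cannot be read because both values are limits: the limit of > 298000 nM in this assay, at which 1 of the 3 values shown sits.

Which of these two compounds is tolerated better therefore stays unknown, as does how far either lies beyond its limit. A plain phenyl ring or a pyridin-3-yl ring at this place could help separate the effect of losing the chlorine atom from that of bringing in ring nitrogen atoms, but the compounds shown do not settle that question.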